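This account rests on a few compounds, and the source may have more. Where it says the series, first, only, none or still open, it means among the compounds named here.

Working notes on the series, assessed in an assay on CHO-K1 cells for binding affinity to muscarinic acetylcholine receptor M5 (Homo sapiens); on this read-out lower numbers stand for stronger inhibition and higher numbers for weaker inhibition.

Three compounds have numbers. Compound 1 `COc1ccc2c(c1)C(C(C)c1ccccn1)=C(CCN(C)C)C2` gives 8910 nM. Compound 2 `CC(C1=C(CCN2CCCCC2)Cc2ccccc21)c1ccccn1` gives 2340 nM. Compound 3 `CC(C1=C(CCN2CCCC2)Cc2ccccc21)c1ccccn1` gives 2000 nM, the lowest of the three numbers, though its gap to compound 2 is within the scatter; only the gap to compound 1 lies beyond it. Among the compounds with values here, the one step between neighbours that differ in a single place is a 1.2-fold lower number from compound 2 to compound 3 (0.07 log units; within the scatter), so swapping one ring amine for another at this position has not moved the number.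

Compound 4 `CC(C1=C(CCN(C)C(C)C)Cc2ccccc21)c1ccccn1` is not yet measured. It differs from compound 3 as follows: isopropyl(methyl)amino in place of pyrrolidin-1-yl on a saturated chain carbon, two bonds along the chain from a double-bonded ring carbon. Again the change is confined to the amine at the end of the two-carbon chain, now opening the ring to an acyclic amine rather than changing ring size. Compound 1 also carries an acyclic amine here, but it differs from compound 3 in two places, so its number alone cannot be read as a step for this change. Within the data shown here, the only step that bears directly on the position is the one from compound 2 to compound 3, which was within the scatter. The expectation is therefore a step of about a 1.4-fold higher number from compound 3 to compound 4 (0.15 log units; within the scatter) in this assay, that is no change beyond the scatter, with some allowance for the acyclic amine being untested on this core. Compound 4 is estimated at 2800 nM, within a range of 1200 nM to 6500 nM.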

Compound 4, inhibition constant: 2190 nM
Estimate against measurement, compound 4: 1.3-fold (0.11 log units) above; measured number inside the range.
By their numbers in this assay, from the lowest: compounds 3, 4 and 2 (each within the scatter of the next); then compound 1.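

In this assay, the end of the chain tolerates more than a change of ring size: isopropyl(methyl)amino in place of pyrrolidin-1-yl gives a 1.1-fold higher number from compound 3 to compound 4 (0.04 log units; within the scatter), and isopropyl(methyl)amino in place of piperidin-1-yl gives a 1.1-fold lower number from compound 2 to compound 4 (0.03 log units; within the scatter). Within the data shown here, earlier, the only readable step at this position compared one ring amine with another; these two steps show that, on the shared core, an amine without a ring cannot be told apart from either ring amine. For compounds 2, 3 and 4, the ring itself therefore shows no measurable contribution to the number, and that reading extends no further than these three compounds. No supporting measurement bears on why the three amines read alike.

The compounds shown leave open whether this tolerance extends to a morpholin-4-yl group, a primary amine or an amide at the end of the chain, or to a longer chain carrying the same amines. They also leave open how much of the gap to compound 1 belongs to its dimethylamino group and how much to its methoxy group, as compound 1 differs from the others in two places.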